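Swapping a Branched for a Straight Chain on an Amine

The source may report more compounds than this note shows. Statements on the series, on what has been measured and on what is new or still open speak of the compounds shown alone.

Measured so far in an ADME assay on MT4 cells (Homo sapiens) for cytotoxicity, read by MTT assay, with a stated time of 5 days; on this read-out lower numbers stand for higher toxicity in this test and higher numbers for lower toxicity in this test:
Compound 1, `CNC(c1ccc(/C=C/C#N)cc1)c1ccnc(Nc2ccc(C#N)cc2)n1`, gives 41400 nM.
Compound 2, `CCCNC(c1ccnc(Nc2ccc(C#N)cc2)n1)c1ccccc1Cl`, gives 68500 nM.
Compound 3, `CC(C)NC(c1ccc(/C=C/C#N)cc1)c1ccnc(Nc2ccc(C#N)cc2)n1`, gives 32300 nM.

Compound 3 shows the smallest of these three numbers, but its gap to compound 1 is within the scatter, and only compound 2 stands apart from it beyond the scatter. Compound 4, `CCCNC(c1ccc(/C=C/C#N)cc1)c1ccnc(Nc2ccc(C#N)cc2)n1`, differs from compound 3 in a single place: propyl in place of isopropyl on an amine nitrogen. The two compounds contain the same atoms, joined differently.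

For the measured compounds named here, the only measured step at the same position is a 1.3-fold lower number from compound 1 to compound 3 (0.11 log units; within the scatter), in which a larger group on the amine nitrogen left the number within the scatter. Going by the values given here, no measured pair compares a branched and a straight chain of the same size, so the expectation rests on that one step alone. Because a 1.3-fold lower number from compound 1 to compound 3 (0.11 log units; within the scatter) stayed within the scatter, the change from isopropyl to propyl is expected to leave the number within the scatter as well, with no direction favoured. Compound 4 is therefore estimated at 35000 nM, with a range from 17000 nM to 70000 nM. This estimate corresponds to an expected step of a 1.1-fold higher number from compound 3 to compound 4 (0.03 log units; within the scatter).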

Compound 4, half-maximal cytotoxic concentration: 34000 nM
Estimate against measurement, compound 4: 1.0-fold (0.01 log units) above, and the stated range covers the measured number.
By their numbers in this assay, from the lowest: compounds 3, 4, 1 and 2 (each within the scatter of the next, the first and the last beyond it).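

In this assay, for the compounds shown here, the step from the branched isopropyl to the straight propyl on the amine nitrogen, with the same atoms joined differently, is a 1.1-fold higher number from compound 3 to compound 4 (0.02 log units; within the scatter) and adds the first direct comparison of two chain shapes at this position, which the scatter cannot tell apart. Measured against the methyl of compound 1, the propyl chain also stays within the scatter, at a 1.2-fold lower number from compound 1 to compound 4 (0.09 log units; within the scatter), so neither the shape nor the length of the chain separates these compounds on this read-out. The step with propyl kept on the nitrogen, 4-(2-cyanoethenyl)phenyl in place of 2-chlorophenyl, is a 2.0-fold lower number from compound 2 to compound 4 (0.30 log units; within the scatter) and also stays within the scatter, and no outside measurement explains why any of these numbers fall as they do.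

The compounds shown leave open whether a ring such as cyclopropyl, a bulkier branched group such as tert-butyl, or a longer chain such as butyl on the amine nitrogen would stay within the scatter too. They also leave open whether isopropyl and propyl would still read alike in a compound that carries 2-chlorophenyl.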